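Aryl Variation on a Hydrazone Series Against PC-3 Cells

This account rests on a few compounds, and the source may have more. Where it says the series, first, only, none or still open, it means among the compounds named here.

Measured so far:
- compound 1, `Cc1cccc(/C=N/Nc2ncc3c(n2)n(C2CCCC2)c(=O)c(=O)n3C)c1`: 53600 nM
- compound 2, `Cn1c(=O)c(=O)n(C2CCCC2)c2nc(N/N=C/c3ccc(C(F)(F)F)cc3)ncc21`: 23600 nM

Both compounds were tested in a functional assay on PC-3 cells (Homo sapiens) for antiproliferative activity, read by MTT assay; on this read-out higher numbers stand for weaker inhibition and lower numbers for stronger inhibition. Compound 1 gives 53600 nM, and compound 2 gives 23600 nM. Among these two numbers compound 2 holds the lower one, and the only measured step in the set, a 2.3-fold lower number from compound 1 to compound 2 (0.36 log units; beyond the scatter), separates it from compound 1.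

Compound 3, `Cn1c(=O)c(=O)n(C2CCCC2)c2nc(N/N=C/c3ccc(F)cc3Cl)ncc21`, has not yet been measured. It differs from compound 2 in one place: 2-chloro-4-fluorophenyl in place of 4-(trifluoromethyl)phenyl on a carbon with a double bond to nitrogen. For the measured compounds named here, the one measured step concerns the same position on a carbon with a double bond to nitrogen, but exchanges a different pair of aryl groups, so it bears on the case only by showing that a change of the aryl group at this place can move this assay modestly. Going by the values given here, no measured step carries a 2-chloro-4-fluorophenyl group. Compound 3 is therefore expected to sit near compound 2, with a step of a 1.3-fold higher number from compound 2 to compound 3 (0.10 log units; within the scatter) that may fall within the scatter in either direction. The estimate for compound 3 in this assay is 30000 nM, with a range from 10000 nM to 90000 nM.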

Compound 3, half-maximal inhibitory concentration: 15200 nM
Estimate against measurement, compound 3: 2.0-fold (0.30 log units) above; measured number inside the range.
By their numbers in this assay, from the lowest: compounds 3 and 2 (each within the scatter of the next); then compound 1.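

In this assay, the step to 2-chloro-4-fluorophenyl in place of 4-(trifluoromethyl)phenyl on a carbon with a double bond to nitrogen is a 1.6-fold lower number from compound 2 to compound 3 (0.19 log units; within the scatter) and so lies within the scatter, which means this read-out does not separate these two aryl groups, different as their substituents are. Set against the 3-methylphenyl group, the same position gives a 3.5-fold lower number from compound 1 to compound 3 (0.55 log units; beyond the scatter) and thus a second modest step beyond the scatter, so among these three compounds the two whose aryl groups carry fluorine both stand apart from compound 1, and none of the three goes against this. No measurement is at hand that would explain either step.

On these data alone, what an aryl group carrying an amine or a carboxylic acid would do at this place remains open, as does the effect of a ring containing nitrogen in place of the carbon-only aromatic rings seen so far. As far as these compounds go, it is also open how much of the step from compound 1 belongs to the chlorine and how much to the fluorine of the 2-chloro-4-fluorophenyl group, and whether either atom alone would give the same result.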